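The source may hold more compounds than are shown below. What is called first, only, known or untested is meant among the compounds shown, and "the series" means these compounds.

Two cinnamoyl-type compounds built on a shared core have been tested in a functional assay on HCT-116 cells (Homo sapiens) for cytotoxicity, read by MTT assay, with a stated time of 48 h; a lower number here means a stronger inhibitor, a higher number a weaker inhibitor. Compound 1 `O=C(/C=C/c1ccc2c(c1)B(O)OC2)c1cccnc1` carries a pyridin-3-yl group on its carbonyl carbon, and in this assay compound 1 gives 20500 nM. Compound 2 `CCc1ccc(C(=O)/C=C/c2ccc3c(c2)B(O)OC3)cc1` carries an ethyl-substituted phenyl group in the same place, and in this assay compound 2 gives 10900 nM. Compound 1 has the higher of these two numbers, but the gap to compound 2 lies within the usual scatter of repeated measurements, so the two cannot be told apart.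

Compound 3 `O=C(/C=C/c1ccc2c(c1)B(O)OC2)c1ccccc1O` is the next compound to be measured. It differs from compound 1 in one place: 2-hydroxyphenyl in place of pyridin-3-yl on a carbonyl carbon. Among the measured compounds shown here, no measured pair shows what this change does, so the expectation for compound 3 rests only on the two numbers above, which are both weak and differ by no more than the scatter. Compound 3 is therefore expected to show no step beyond the scatter, with a 1.4-fold lower number from compound 1 to compound 3 (0.14 log units; within the scatter) as the estimated step. Compound 3 is estimated at 15000 nM, with a likely range from 5000 nM to 45000 nM.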

Compound 3, half-maximal inhibitory concentration: 77900 nM
For compound 3 the middle estimate is 5.2-fold (0.72 log units) below the measured one, outside the stated range (above it).
By their numbers in this assay, from the lowest: compounds 2 and 1 (each within the scatter of the next); then compound 3.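

Swapping the group on the carbonyl carbon can matter: in this assay, 2-hydroxyphenyl in place of pyridin-3-yl gives a 3.8-fold higher number from compound 1 to compound 3 (0.58 log units; beyond the scatter) and so makes compound 3 a weaker inhibitor than compound 1. Among the compounds shown here, this modest step is the first here to stand clear of the scatter, whereas the two groups on compound 1 and compound 2 could not be told apart, so this position is now seen to tolerate some groups less well than others. No measurement shown here gives a reason for this step.

A single pair also cannot separate the part played by the hydroxyl group from that of the ring carrying it, and a plain phenyl group would be the direct test of this. Going by these compounds, it also remains open whether an amine or a carboxylic acid in place of the hydroxyl on that ring would bring the number back towards that of compound 1 or push it higher still.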